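Changing the Aryl Group on the Ring Nitrogen

A few compounds are considered here, and "the series" means these few. Any claim that something is new, unique, unknown or untested is made for them only; others in the source may bear on it.

Compound 2 `N#CC1=C(N)Oc2c(N)cc3nc4ccccc4nc3c2C12C(=O)N(Cc1cnnn1-c1c(Cl)cc(Cl)cc1Cl)c1ccccc12` holds the lowest of the two numbers measured in an ADME assay on HUVEC cells (Homo sapiens) for antiproliferative activity, read by MTT assay, with a stated time of 48 h (on this read-out higher numbers stand for weaker inhibition and lower numbers for stronger inhibition), where compound 2 gives 18300 nM. Its nearest neighbour, compound 1 `N#CC1=C(N)Oc2c(N)cc3nc4ccccc4nc3c2C12C(=O)N(Cc1cnnn1-c1ccccc1Br)c1ccccc12`, gives 34200 nM in this assay, and a 1.9-fold lower number from compound 1 to compound 2 (0.27 log units; within the scatter). Compound 3 `COc1cc(-n2nncc2CN2C(=O)C3(C(C#N)=C(N)Oc4c(N)cc5nc6ccccc6nc5c43)c3ccccc32)c(OC)cc1Cl` differs from compound 2 by 4-chloro-2,5-dimethoxyphenyl in place of 2,4,6-trichlorophenyl on an aromatic nitrogen. For the measured compounds named here, the only measured step bearing on an aryl change at this nitrogen is the one from compound 1 to compound 2, and it stayed within the scatter. A step of similar size is therefore expected, namely a 1.2-fold higher number from compound 2 to compound 3 (0.08 log units; within the scatter), with no direction beyond the scatter. Compound 3 is accordingly estimated at 22000 nM, within a range from 8000 nM to 60000 nM.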

Compound 3, half-maximal inhibitory concentration: > 50000 nM
Compound 3 ended at the assay's limit; the forecaster's own chance of this, stated with the estimate: 15%; middle value at least 2.2-fold (0.35 log units) away from the limit.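

The result for compound 3 is a limit of the assay, not a number: the limit of > 50000 nM in this assay, at which 1 of the 3 values shown sits. Even so, 4-chloro-2,5-dimethoxyphenyl in place of 2,4,6-trichlorophenyl gives an at least 2.7-fold higher number from compound 2 to compound 3 (0.43 log units; beyond the scatter), which shows that this position can respond to an aryl change, as the earlier step did not. Against 2-bromophenyl, the same group gives an at least 1.4-fold higher number from compound 1 to compound 3 (0.16 log units; that floor lies within the scatter), so that comparison shows only a floor and no clear separation.

The compounds shown leave open whether the methoxy groups or the change in chlorine substitution carries the larger step. They also leave open how an aryl ring bearing an amine or a carboxylic acid would read here.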